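Compound 2 to compound 4: a fluoro step

The compounds below may be only part of what the source reports. "The series", "measured", "known", "first", "only" and "open" are said of these compounds alone.

Measured so far in an ADME assay on HaCaT cells (Homo sapiens) for cytotoxicity, read by MTT assay, with a stated time of 48 h; a higher number here means a weaker inhibitor, a lower number a stronger inhibitor
Compound 1 `Cc1ccc2[nH]c(-c3cn(-c4ccccc4)nc3-c3ccccc3)nc2c1` gives > 50000 nM, a limit
Compound 2 `Cc1cc2nc(-c3cn(-c4ccccc4)nc3-c3ccccc3)[nH]c2cc1C` gives > 50000 nM, a limit
Compound 3 `Clc1cc2nc(-c3cn(-c4ccccc4)nc3-c3ccccc3)[nH]c2cc1Cl` gives 29700 nM

Compound 2 stands at the limit of > 50000 nM in this assay, at which 2 of the 3 values shown sit, so it has no number to start from. Compound 4 `Cc1cc2nc(-c3cn(-c4ccccc4)nc3-c3ccc(F)cc3)[nH]c2cc1C` differs from it by fluoro in place of hydrogen on an aromatic carbon. Among the measured compounds shown here, no measured step covers this change. The nearest is a step that the two limits leave unreadable from compound 1 to compound 2, which gives no size to carry over. No step beyond the scatter is therefore expected in this assay, and another limit is the likeliest report. The low end of the range allows for a value near that of compound 3 at 29700 nM in the same assay series. The estimated step is a number no higher from compound 2 to compound 4 (the limit leaves the size open) as the expected outcome. For compound 4 the estimated value is 50000 nM, expected to fall between 25000 nM and 100000 nM as a range.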

Compound 4, half-maximal inhibitory concentration: > 50000 nM
Compound 4: no number, only a limit; the forecaster's own chance of this, stated with the estimate: 65%; the middle value lies on the limit itself.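

Compound 2 and compound 4 both stand only as limits in this assay, so no step between them can be read: the limit of > 50000 nM in this assay, at which 3 of the 4 values shown sit.

The compounds shown leave open whether phenyl to 4-fluorophenyl shifts the value at all, and by how much.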